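Methylating the Hydroxymethyl Group: Expected Effect on Cytotoxicity

The compounds below may be only part of what the source reports. "The series", "measured", "known", "first", "only" and "open" are said of these compounds alone.

Measured so far in a functional assay on MT2 cells (Homo sapiens) for cytotoxicity, read by MTT assay; on this read-out higher numbers stand for lower toxicity in this test and lower numbers for higher toxicity in this test:
compound 1 `CSc1ccnc(Nc2ccc(Cl)c(OCC=C(C)C)c2)n1`: 2800 nM
compound 2 `CC(C)=CCOc1cc(Nc2nccc(CO)n2)ccc1Cl`: 220 nM

Compound 2 stands lowest of the two numbers, meaning it is the more cytotoxic of the pair in this assay. Among the compounds with values here, its only neighbour is compound 1, and the single step between them, a 13-fold lower number from compound 1 to compound 2 (1.10 log units; beyond the scatter), is large and well beyond the scatter. That step consisted of hydroxymethyl in place of methylsulfanyl on an aromatic carbon, so changes at this group clearly move the number a great deal.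

Compound 3 `COCc1ccnc(Nc2ccc(Cl)c(OCC=C(C)C)c2)n1` differs from compound 2 by methyl in place of hydrogen on an oxygen on a saturated carbon. Cut one bond further out, the change reads hydroxy to methoxy, or hydroxymethyl to methoxymethyl. Within the data shown here, no measured step covers this exact change; only a 13-fold lower number from compound 1 to compound 2 (1.10 log units; beyond the scatter) bears on it, showing that compound 2, with its hydroxymethyl group, sits far below compound 1. Compound 3 keeps the oxygen on that carbon but caps it, so a number somewhere between the two measured values seems most likely, and a step in this assay of moderate size upward is expected.

Compound 3 is therefore expected to give about 600 nM. The expected range for compound 3 runs from 200 nM to 2000 nM. The expected step is a 2.7-fold higher number from compound 2 to compound 3 (0.44 log units; beyond the scatter).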

Compound 3, half-maximal cytotoxic concentration: > 25000 nM
Compound 3 ended at the assay's limit (the forecaster's own chance of this, stated with the estimate: 5%); middle value at least 41-fold (1.61 log units) away from the limit.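

In this assay, the single methyl added on the oxygen gives an at least 110-fold higher number from compound 2 to compound 3 (2.05 log units; beyond the scatter), so it is the free hydroxy group at this position, and not merely an oxygen on that saturated carbon, that goes with the low number of compound 2. The methoxymethyl group also ends on the far side of methylsulfanyl, with an at least 8.9-fold higher number from compound 1 to compound 3 (0.95 log units; beyond the scatter), so among these three groups the order on this aromatic carbon is not the one that the first pair alone suggested, and a small cap on the oxygen can separate two otherwise identical molecules very widely. The value of compound 3 is a limit of the assay and not a number: the limit of > 25000 nM in this assay, at which 1 of the 3 values shown sits.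

The compounds shown leave open whether the low number of compound 2 depends on the hydroxy group as such, which an amine or a carboxylic acid on that carbon would help to test, or whether a longer chain on the oxygen would behave like the methyl. Only this one read-out is shown, so whether the same order holds in any other test remains unknown.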